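Replacing furan-3-yl with 5-cyanopyridin-3-yl in compound 2

The compounds below may be only part of what the source reports. "The series", "measured", "known", "first", "only" and "open" are said of these compounds alone.

In a toxicity assay on MT4 cells (Homo sapiens) for cytotoxicity, read by MTT assay, with a stated time of 5 days (a lower number here means that less compound is tolerated, a higher number that more compound is tolerated), compound 1 (`Cc1cnc(Nc2ccc(C#N)cc2)nc1Nc1c(F)cc(-c2cncnc2)cc1F`), carrying pyrimidin-5-yl, gives 900 nM. Compound 2 (`Cc1cnc(Nc2ccc(C#N)cc2)nc1Nc1c(F)cc(-c2ccoc2)cc1F`), carrying furan-3-yl, gives 4200 nM. Compound 3 (`Cc1cnc(Nc2ccc(C#N)cc2)nc1Nc1c(F)cc(-c2ccsc2)cc1F`), carrying thiophen-3-yl, gives 261000 nM. Compound 2 therefore holds the second highest of the three numbers, much closer to compound 1 than to compound 3.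

The change under review leads to compound 4 (`Cc1cnc(Nc2ccc(C#N)cc2)nc1Nc1c(F)cc(-c2cncc(C#N)c2)cc1F`), not yet measured: 5-cyanopyridin-3-yl in place of furan-3-yl on an aromatic carbon. Here 5-cyanopyridin-3-yl takes the place of furan-3-yl on an aromatic carbon, para to a large group.

All three measured steps concern this same place. The modest one is a 4.7-fold higher number from compound 1 to compound 2 (0.67 log units; beyond the scatter), while a 62-fold higher number from compound 2 to compound 3 (1.79 log units; beyond the scatter) and a 290-fold higher number from compound 1 to compound 3 (2.46 log units; beyond the scatter) are both large. For the measured compounds named here, no measured compound carries 5-cyanopyridin-3-yl. Going by the values given here, compound 1, at 900 nM, is the only measured compound with a six-membered aromatic ring at this place, so it serves as the nearest guide and suggests a slight drift toward a lower number in this assay, though no step beyond the scatter is expected. The estimated step is a 1.4-fold lower number from compound 2 to compound 4 (0.15 log units; within the scatter). The expected range stays wide, given the size of a 62-fold higher number from compound 2 to compound 3 (1.79 log units; beyond the scatter). Compound 4 is estimated at 3000 nM, with an expected range from 500 nM to 30000 nM.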

Compound 4, half-maximal cytotoxic concentration: 50000 nM
The estimate for compound 4 lay 17-fold (1.22 log units) below the measured number; the whole stated range lies below it.
By their numbers in this assay, from the lowest: compound 1; then compound 2; then compound 4; then compound 3.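

In this assay, ring size alone does not set the number at this position: two six-membered aromatic rings are far apart, with a 56-fold higher number from compound 1 to compound 4 (1.74 log units; beyond the scatter), so the nitrile-bearing pyridine does not behave like pyrimidin-5-yl. The five-membered rings do not sort to one side of compound 4 either, as a 12-fold higher number from compound 2 to compound 4 (1.08 log units; beyond the scatter) and a 5.2-fold lower number from compound 3 to compound 4 (0.72 log units; beyond the scatter) place compound 4 inside the span set by furan-3-yl and thiophen-3-yl. Among the four compounds, the tolerated concentration therefore follows the particular group rather than its ring class, and nothing available explains these differences.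

The compounds shown leave open whether the rise from compound 1 to compound 4 follows the nitrile or the change of ring atoms, a question that plain pyridin-3-yl, with a hydrogen in place of the nitrile, would address directly. Going by these compounds, it also remains open whether another group at the same ring carbon of 5-substituted pyridin-3-yl, such as an amine or a carboxylic acid, would give a number closer to that of compound 1 or that of compound 4.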